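A Bromo for Nitro Swap in a Cytotoxicity Assay

A few compounds are considered here, and "the series" means these few. Any claim that something is new, unique, unknown or untested is made for them only; others in the source may bear on it.

Measured in an ADME assay on MDCK cells (Canis lupus familiaris) for cytotoxicity, read by MTT assay, with a stated time of 24 h; a higher number here means that more compound is tolerated, a lower number that less compound is tolerated:
Compound 1 `Cc1cc(CNS(=O)(=O)c2ccc(Cl)cc2)c(C)s1`: 52900 nM
Compound 2 `O=[N+]([O-])c1ccc(S(=O)(=O)NCc2csc3ccccc23)cc1`: > 191000 nM

Compound 2 stands at a limit of the assay, > 191000 nM, and so has no exact number. Compound 3 `O=S(=O)(NCc1csc2ccccc12)c1ccc(Br)cc1` has not yet been measured. It differs from compound 2 at one place, with bromo in place of nitro on an aromatic carbon, para to a large group: bromo in place of nitro on an aromatic carbon. For the measured compounds named here, no measured pair in this assay shows this change alone, so the size of the step can only be estimated. With no nitro group, and differing from compound 2 elsewhere as well, compound 1 gives 52900 nM. On that value, a moderately lower tolerated concentration is expected, beyond the usual scatter. The expected change is an at least 2.2-fold lower number from compound 2 to compound 3 (0.35 log units; beyond the scatter). For compound 3, the estimated value is 85000 nM, with an expected range from 30000 nM to 220000 nM.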

Compound 3, half-maximal cytotoxic concentration: 87100 nM
Compound 3: middle estimate off by 1.0-fold (0.01 log units), on the low side; the range from low to high includes it.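

Compound 1 differs from compound 2 in more than one place, so it could not isolate this position; the new pair does. On an aromatic carbon para to a large group, bromo in place of nitro alone gives an at least 2.1-fold lower number from compound 2 to compound 3 (0.34 log units; beyond the scatter) in this assay, which shows that this single change is enough to move the tolerated concentration beyond the usual scatter. The true size of the step stays open on one side, because compound 2 stands at a limit and not at an exact number: the limit of > 191000 nM in this assay, at which 1 of the 3 values shown sits.

The pair cannot separate the loss of nitro from the gain of bromo, since no compound with plain hydrogen at this position is among those shown. Going by these compounds, how an amine, a carboxylic acid or a methoxy group would fare at the same place also remains open.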